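From Methyl to Methoxymethyl: One Step from Compound 3

A few compounds are considered here, and "the series" means these few. Any claim that something is new, unique, unknown or untested is made for them only; others in the source may bear on it.

Compound 1 `CCCc1nc2c(C)ccnc2n1Cc1cc(Cl)c(O)c(Cl)c1` gives 1.26 nM
Compound 2 `CCCc1nc2c(Cl)ccnc2n1Cc1ccc(-c2ccccc2C(=O)O)cc1` gives 7.94 nM
Compound 3 `Cc1ccnc2c1nc(C)n2Cc1ccc(-c2ccccc2C(=O)O)cc1` gives 50.1 nM

In a functional assay (aorta) with Oryctolagus cuniculus as the target (a higher number here means weaker binding, a lower number tighter binding), compound 3 (50.1 nM) has the highest number of the three, and its gaps to compound 2 and compound 1 both lie beyond the scatter. Compound 4 `COCc1nc2c(C)ccnc2n1Cc1ccc(-c2ccccc2C(=O)O)cc1` has not yet been measured. It departs from compound 3 by methoxy in place of hydrogen on a saturated chain carbon bound to an aromatic carbon which turns methyl into methoxymethyl. For the measured compounds named here, no measured pair differs in one place only, so the evidence for this step is indirect. Compound 2 (7.94 nM) carries propyl rather than methyl and also differs from compound 3 elsewhere, so it offers only a weak hint that a larger group may lower the number. On that basis, a moderate fall is expected, with the estimated step being a 3.1-fold lower number from compound 3 to compound 4 (0.50 log units; beyond the scatter) and wide uncertainty around it. The estimate for compound 4 is 16 nM with an expected range from 4 nM to 50 nM in the measurement still to come.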

Compound 4, dissociation constant: 79.4 nM
Estimate against measurement, compound 4: 5.0-fold (0.70 log units) below; the whole stated range lies below it.
By their numbers in this assay, from the lowest: compound 1; then compound 2; then compounds 3 and 4 (each within the scatter of the next).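

In this assay, for the compounds shown here, the change from methyl to methoxymethyl gives a 1.6-fold higher number from compound 3 to compound 4 (0.20 log units; within the scatter) and is the first change in this set that can be read on its own, with only one place differing. Methoxy in place of hydrogen on this saturated chain carbon bound to an aromatic carbon therefore adds 2 heavy atoms and 1 hydrogen-bond acceptor without moving the result beyond the scatter, so the two groups cannot be told apart here. Nothing among the available data accounts for this outcome.

Going by these compounds, it remains open whether a chain without oxygen, such as propyl, would behave the same way at this position on the core of compound 3. An amine or a hydroxyl group on this carbon also remains untested among the compounds shown, as does a longer ether chain.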